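A few compounds are considered here, and "the series" means these few. Any claim that something is new, unique, unknown or untested is made for them only; others in the source may bear on it.

Measured so far:
- compound 1, `Cc1ccc(S(=O)(=O)n2cnc3c(Cl)ncnc32)cc1`: 20800 nM
- compound 2, `Cc1ccc(S(=O)(=O)n2cnc3c(N4CCN(c5ccc(C(F)(F)F)cc5)CC4)ncnc32)cc1`: 1400 nM

Among the compounds with values here, in a functional assay on Huh-7 cells (Homo sapiens) for cytotoxicity, read by sulforhodamine B assay, with a stated time of 72 h (on this read-out lower numbers stand for stronger inhibition and higher numbers for weaker inhibition), compound 1 stands at the highest of the two numbers on record; the only neighbour, compound 2, lies well below it, and the gap between the two is beyond the usual scatter. Compound 3, `Cc1ccc(S(=O)(=O)n2cnc3c(NCCC4C=CCCC4)ncnc32)cc1`, is the next candidate and differs from compound 1 in one place: (2-(cyclohex-2-en-1-yl)ethyl)amino in place of chloro on an aromatic carbon. Within the data shown here, no pair of measured compounds documents this exact exchange, so the expected size of the step rests on one observation only. The direction is expected to be downward, i.e. towards stronger inhibition in this assay, because compound 2 gives 1400 nM after a chloro-to-amine replacement at the same position. Among the measured compounds shown here, the expected step from compound 1 to compound 3 is put at a 4.2-fold lower number from compound 1 to compound 3 (0.62 log units; beyond the scatter), smaller than the one seen for compound 2. Compound 3 is estimated at 5000 nM, with a range of 1500 nM to 16000 nM.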

Compound 3, half-maximal inhibitory concentration: 9400 nM
Beside the measured number, compound 3's estimate is 1.9-fold (0.27 log units) below it; measured number inside the range.
By their numbers in this assay, from the lowest: compound 2; then compound 3; then compound 1.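

In this assay the exchange of chloro for (2-(cyclohex-2-en-1-yl)ethyl)amino on this aromatic carbon gives a 2.2-fold lower number from compound 1 to compound 3 (0.34 log units; beyond the scatter) as a modest step, so this position accepts a secondary amine bearing a non-aromatic carbon ring. The amine alone does not fix the level: compound 3 gives 9400 nM while compound 2, with its aryl-substituted cyclic amine, gives 1400 nM at the same position. Nothing on hand accounts for the size of this step.

Open, on these data alone, is which part of the new group matters: the ring double bond, the ring itself or the amine hydrogen. A saturated 2-cyclohexylethylamino group, a plain butylamino chain and a morpholine at this position would separate these.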